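The source may report more compounds than this note shows. Statements on the series, on what has been measured and on what is new or still open speak of the compounds shown alone.

Measured in a functional assay on HeLa cells (Homo sapiens) for inhibition, read by MTT assay, with a stated time of 48 h; a lower number here means a stronger inhibitor, a higher number a weaker inhibitor:
- Compound 1 `CCOC(=O)C1=C(N/N=C(\c2ccc([N+](=O)[O-])cc2)N2CCN(c3ccc(F)cc3)CC2)Nc2[nH]nc(C)c2C1c1ccc(N(C)C)cc1`: 87000 nM
- Compound 2 `CCOC(=O)C1=C(N/C=N/c2nnc(S(N)(=O)=O)s2)Nc2[nH]nc(C)c2C1c1ccc(N(C)C)cc1`: 26300 nM
- Compound 3 `CCOC(=O)C1=C(N/N=C(/C(=O)Br)c2ccc(Br)cc2)Nc2[nH]nc(C)c2C1c1ccc(N(C)C)cc1`: 68500 nM

Of these three, compound 2 gives the lowest number, 26300 nM, making it the strongest inhibitor so far. Compound 4 `CCOC(=O)C1=C(NN=C(C#N)C#N)Nc2[nH]nc(C)c2C1c1ccc(N(C)C)cc1` differs from it in one place: a group of 6 heavy atoms (3 carbon, 3 nitrogen; no ring) in place of a group of 11 heavy atoms (3 carbon, 4 nitrogen, 2 oxygen, 2 sulfur; one five-membered aromatic ring with 3 hetero atoms), on an amine nitrogen. The change lies on an amine nitrogen whose other neighbours are: double-bonded ring carbon.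

Among the measured compounds shown here, only one measured step removes the same group from compound 2: a 2.6-fold higher number from compound 2 to compound 3 (0.42 log units; beyond the scatter). That step was modest. Compound 1, at 87000 nM, also stands higher. In this assay, a modest rise is therefore expected, with this estimated step: a 2.3-fold higher number from compound 2 to compound 4 (0.36 log units; beyond the scatter). The expected value for compound 4 is 60000 nM, within an estimated range of 20000 nM to 150000 nM.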

Compound 4, half-maximal inhibitory concentration: 15200 nM
Estimate against measurement, compound 4: 3.9-fold (0.60 log units) above, and the stated range ends above it.
By their numbers in this assay, from the lowest: compounds 4 and 2 (each within the scatter of the next); then compounds 3 and 1 (each within the scatter of the next).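

At this amine nitrogen, a group with no ring can stand in for the one with a five-membered aromatic ring: in this assay the swap gives a 1.7-fold lower number from compound 2 to compound 4 (0.24 log units; within the scatter) and that step lies within the scatter, so the two compounds stand level. Set against the group with a six-membered aromatic ring and two bromines, the same small group gives a 4.5-fold lower number from compound 3 to compound 4 (0.65 log units; beyond the scatter) and this modest step lies beyond the scatter. Nothing measured here gives a reason for either step. Still open, on these data alone, is whether a single nitrile, an amine or a carboxylic acid on this nitrogen's group would hold the same level.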